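A few compounds are considered here, and "the series" means these few. Any claim that something is new, unique, unknown or untested is made for them only; others in the source may bear on it.

Measured compounds in a functional assay on C8166 cells (Homo sapiens) for cytotoxicity, read by MTT assay; a higher number here means that more compound is tolerated, a lower number that less compound is tolerated:
compound 1 `Cc1cccc(C(=O)Nc2cc(Cl)ccc2OCC(=O)Nc2ccc(S(N)(=O)=O)cc2C)c1` gives 52900 nM
compound 2 `Cc1cc(S(N)(=O)=O)ccc1NC(=O)COc1ccc(Cl)cc1NC(=O)c1cccc(C(F)(F)F)c1` gives 124000 nM
compound 3 `Cc1ccc(C(=O)Nc2cc(Cl)ccc2OCC(=O)Nc2ccc(S(N)(=O)=O)cc2C)cc1C` gives 84100 nM

Compound 2 has the highest of the three numbers in this assay. Its distance from compound 1 is a 2.3-fold higher number from compound 1 to compound 2 (0.37 log units; beyond the scatter), a modest step beyond the scatter, while its distance to compound 3 is a 1.5-fold lower number from compound 2 to compound 3 (0.17 log units; within the scatter), which stays within the scatter. Compound 1 and compound 3 differ by a 1.6-fold higher number from compound 1 to compound 3 (0.20 log units; within the scatter), also within the scatter.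

Compound 4 `Cc1cc(S(N)(=O)=O)ccc1NC(=O)COc1ccc(Cl)cc1NC(=O)c1cc(Cl)cc(C#N)c1` has not been measured. Relative to compound 2 the change is 3-chloro-5-cyanophenyl in place of 3-(trifluoromethyl)phenyl on a carbonyl carbon. Going by the values given here, the most relevant measured step is the one from compound 2 to compound 3, where the same 3-(trifluoromethyl)phenyl was exchanged for another substituted phenyl on the carbonyl carbon and the number barely moved. The step from compound 1 to compound 2 shows that a single substituent exchange on that ring can shift the number modestly. On this basis compound 4 is expected to land close to compound 2, with no step beyond the scatter. The expected step is a 1.2-fold lower number from compound 2 to compound 4 (0.09 log units; within the scatter). Compound 4 is estimated at 100000 nM, with a range from 45000 nM to 220000 nM.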

Compound 4, half-maximal cytotoxic concentration: 131000 nM
Estimate against measurement, compound 4: 1.3-fold (0.12 log units) below; the range from low to high includes it.
By their numbers in this assay, from the lowest: compounds 1, 3, 2 and 4 (each within the scatter of the next, the first and the last beyond it).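

In this assay the exchange of 3-(trifluoromethyl)phenyl for 3-chloro-5-cyanophenyl on the carbonyl carbon stays within the scatter (a 1.1-fold higher number from compound 2 to compound 4 (0.02 log units; within the scatter)), which shows that this position can take a ring with a nitrile and a chlorine, and thus a triple bond and a hydrogen-bond acceptor, without a step beyond the scatter. The comparison with 3,4-dimethylphenyl also stays within the scatter (a 1.6-fold higher number from compound 3 to compound 4 (0.19 log units; within the scatter)), whereas the comparison with 3-methylphenyl lies beyond it (a 2.5-fold higher number from compound 1 to compound 4 (0.39 log units; beyond the scatter)), so compound 1 stands apart from compound 2 and compound 4 but not from compound 3. No measurement offered here accounts for these numbers.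

The compounds shown leave open whether the chlorine or the nitrile alone would give a similar number. They also leave open whether an amine or a carboxylic acid on this ring, or a pyridine ring in its place, would stay in the same range.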